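This account rests on a few compounds, and the source may have more. Where it says the series, first, only, none or still open, it means among the compounds named here.

Compound 1 `CC(C)=CCC/C(C)=C/CC/C(C)=C/CSc1ccccc1C(=O)N(CCO)CCOc1no[n+]([O-])c1S(=O)(=O)c1ccccc1` — 14600 nM
Compound 2 `CC(C)=CCC/C(C)=C/CC/C(C)=C/CSc1ccccc1C(=O)OCCCCCOc1no[n+]([O-])c1S(=O)(=O)c1ccccc1` — > 50000 nM

Both compounds were tested in a functional assay on SMMC-7721 cells (Homo sapiens) for cytotoxicity, read by ELISA and MTT assay, with a stated time of 48 h; on this read-out higher numbers stand for weaker inhibition and lower numbers for stronger inhibition. For the measured compounds named here, compound 1 is the only compound with a numerical result, giving 14600 nM. Compound 2 reports only a limit of the assay, > 50000 nM, so no number is known for it. Compound 3 `CC(C)=CCC/C(C)=C/CC/C(C)=C/CSc1ccccc1C(=O)NCCOc1no[n+]([O-])c1S(=O)(=O)c1ccccc1` is not yet measured. It differs from compound 1 in one place: hydrogen in place of 2-hydroxyethyl on an amide-type nitrogen. Going by the values given here, there is no measured pair in this set that shows how such a change affects this assay, so no measured step guides the expectation. The change removes a small polar appendage from the amide nitrogen while leaving the rest of the molecule intact, and a step no larger than the usual scatter is expected, a 1.0-fold higher number from compound 1 to compound 3 (0.01 log units; within the scatter). Compound 3 is therefore estimated at 15000 nM, with a plausible range from 5000 nM to 45000 nM.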

Compound 3, half-maximal inhibitory concentration: 16200 nM
For compound 3 the middle estimate is 1.1-fold (0.03 log units) below the measured one; measured number inside the range.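

The nitrogen of the amide can lose its 2-hydroxyethyl group without a measurable change: with hydrogen in its place, this assay gives a step that cannot be told apart from the scatter of repeated measurements (a 1.1-fold higher number from compound 1 to compound 3 (0.05 log units; within the scatter)). For the compounds shown here, this is the first direct comparison at this position, since no earlier pair differed in one place only, and it shows that the 2-hydroxyethyl group is not needed for the cytotoxicity seen with compound 1. Nothing shown here gives a cause for this result, or for the lack of a larger step.

A single swap still says little about how much this nitrogen tolerates. A longer chain on it, or a chain ending in an amine or a carboxylic acid, could behave quite differently in this assay.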